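Amide-nitrogen aryl swaps on a shared quinoline ether core

The compounds below may be only part of what the source reports. "The series", "measured", "known", "first", "only" and "open" are said of these compounds alone.

Measured so far:
Compound 1, `COc1ccc2nc(C)cc(OCC(=O)Nc3c(C)cccc3C)c2c1`: in a toxicity assay on HepG2 cells (Homo sapiens) for inhibition, read by CellTiter-Glo, with a stated time of 48 h (a lower number here means a stronger inhibitor, a higher number a weaker inhibitor), compound 1 gives only a limit, > 100000 nM.
Compound 2, `COc1ccc2nc(C)cc(OCC(=O)Nc3cc(F)cc(F)c3)c2c1`: in this assay compound 2 gives only a limit, > 100000 nM.
Compound 3, `COc1ccc2nc(C)cc(OCC(=O)Nc3cc(C)nc(C)n3)c2c1`: in this assay compound 3 gives only a limit, > 100000 nM.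

Compound 3 therefore stands where both other compounds stand: at the limit of this assay, with no number behind it. The three steps among the measured compounds, a step that the two limits leave unreadable from compound 1 to compound 2, a step that the two limits leave unreadable from compound 1 to compound 3 and a step that the two limits leave unreadable from compound 2 to compound 3, are all unreadable for the same reason, which is the limit of > 100000 nM in this assay, at which 3 of the 3 values shown sit.

Compound 4, `COc1ccc2nc(C)cc(OCC(=O)Nc3noc(C)c3C)c2c1`, has not yet been measured. It differs from compound 3 only in the group on the amide-type nitrogen: 4,5-dimethyl-1,2-oxazol-3-yl in place of 2,6-dimethylpyrimidin-4-yl on an amide-type nitrogen. The measured steps that bear on this change are the three aryl swaps on that same nitrogen, and none of them moved any compound off the limit in this assay. No size of step can be read from them, so no step beyond the scatter is expected in either direction.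

Compound 4 is therefore expected to remain at or around the limit of this assay, estimated at 150000 nM within 40000 nM to 600000 nM, which means an expected step that the limit leaves unreadable from compound 3 to compound 4.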

Compound 4, half-maximal inhibitory concentration: > 100000 nM
Compound 4: no number, only a limit (the forecaster's own chance of this, stated with the estimate: 85%); the middle value is on the limit's open side.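

Compound 4 joins compound 1, compound 2 and compound 3 in this assay with a limit and no number, so none of its steps to those compounds can be read, because all four share one limit: the limit of > 100000 nM in this assay, at which 4 of the 4 values shown sit. The compounds shown leave open whether any group on the amide-type nitrogen gives a numerical value in this assay and how these compounds rank.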